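The source may report more compounds than this note shows. Statements on the series, on what has been measured and on what is new or still open speak of the compounds shown alone.

In a functional assay on A549 cells (Homo sapiens) for antiproliferative activity, read by MTT assay, with a stated time of 48 h (on this read-out lower numbers stand for stronger inhibition and higher numbers for weaker inhibition), compound 1 (`COc1ccc(-c2nn(-c3ccccc3)cc2C(Nc2nc3ccccc3s2)c2c(O)ccc3ccccc23)cc1`) gives 26200 nM and compound 2 (`COc1ccc2nc(NC(c3cn(-c4ccccc4)nc3-c3ccc([N+](=O)[O-])cc3)c3c(O)ccc4ccccc34)sc2c1`) gives 22500 nM. These values lie within the scatter of each other, so compound 2 stands level with compound 1. Compound 3 (`COc1ccc(-c2nn(-c3ccccc3)cc2C(Nc2nc3ccc(OC)cc3s2)c2c(O)ccc3ccccc23)cc1`) differs from compound 2 by methoxy in place of nitro on an aromatic carbon, turning 4-nitrophenyl into 4-methoxyphenyl. Among the measured compounds shown here, no measured pair shows this change, so no step beyond the scatter is expected in this assay, in either direction. The expected step of a 1.1-fold higher number from compound 2 to compound 3 (0.03 log units; within the scatter) stays within the scatter. For compound 3 the estimated value is 24000 nM, with an expected range of 10000 nM to 55000 nM.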

Compound 3, half-maximal inhibitory concentration: 28100 nM
Estimate against measurement, compound 3: 1.2-fold (0.07 log units) below; the range from low to high includes it.
By their numbers in this assay, from the lowest: compounds 2, 1 and 3 (each within the scatter of the next).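

In this assay, 4-methoxyphenyl in place of 4-nitrophenyl gives a 1.2-fold higher number from compound 2 to compound 3 (0.10 log units; within the scatter), the first measured read of this change, and it leaves the number level. Methoxy in place of hydrogen on an aromatic carbon gives a 1.1-fold higher number from compound 1 to compound 3 (0.03 log units; within the scatter), so this second single-place change also leaves the number level. Nothing at hand explains either result. From the compounds shown here alone, whether an amine, a carboxylic acid or a longer chain in place of the methoxy of 4-methoxyphenyl would move the number beyond the scatter remains open.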